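This account rests on a few compounds, and the source may have more. Where it says the series, first, only, none or still open, it means among the compounds named here.

In a functional assay on MDA-MB-435 cells (Homo sapiens) for antiproliferative activity, read by sulforhodamine B assay, with a stated time of 48 h (a higher number here means a weaker inhibitor, a lower number a stronger inhibitor), compound 1 `O=C(Nc1ccc(-n2cc(-c3ccncc3)c(-c3ccc(Cl)c(O)c3)n2)cc1)Nc1ccc(Cl)c(C(F)(F)F)c1` gives 1320 nM. Within the data shown here, compound 2 `O=C(Nc1ccc(-n2cc(-c3ccncc3)c(-c3ccc(Cl)c(O)c3)n2)cc1)c1cc(Cl)cc(Cl)c1` gives 3780 nM in this assay, the highest of the two numbers measured so far; its nearest neighbour is compound 1, and the step of a 2.9-fold higher number from compound 1 to compound 2 (0.46 log units; beyond the scatter) is a modest one that goes beyond the scatter. Compound 3 `O=C(Nc1ccc(-n2cc(-c3ccncc3)c(-c3ccc(Cl)c(O)c3)n2)cc1)c1ccc(Cl)c(C(F)(F)F)c1` has not been measured in this assay. It differs from compound 2 in one place: 4-chloro-3-(trifluoromethyl)phenyl in place of 3,5-dichlorophenyl on a carbonyl carbon. Among the measured compounds shown here, the only measured step that bears on this change is the one from compound 1 to compound 2, which swapped in the 3,5-dichlorophenyl group and also altered the link to the carbonyl carbon, so it is not a clean test of the aryl group alone. Since compound 3 carries the same 4-chloro-3-(trifluoromethyl)phenyl group as compound 1, a modest move toward the number of compound 1 is expected, giving an estimated step of a 1.7-fold lower number from compound 2 to compound 3 (0.24 log units; within the scatter). The estimate for compound 3 in this assay is therefore 2200 nM, with a range from 900 nM to 5500 nM.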

Compound 3, half-maximal inhibitory concentration: 1200 nM
Compound 3: the middle estimate sits 1.8-fold (0.26 log units) above what was measured, and the stated range covers the measured number.
By their numbers in this assay, from the lowest: compounds 3 and 1 (each within the scatter of the next); then compound 2.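

Compound 2 and compound 3 share the same link, an amide-type nitrogen on the carbonyl carbon, so only the aryl group changes between them. In this assay, this gives the clean test of that group that the earlier step could not: a 3.2-fold lower number from compound 2 to compound 3 (0.50 log units; beyond the scatter) when 4-chloro-3-(trifluoromethyl)phenyl replaces 3,5-dichlorophenyl. The other new comparison keeps the aryl group and removes the amino link, and a 1.1-fold lower number from compound 1 to compound 3 (0.04 log units; within the scatter), so among these compounds the aryl group matters here while the link makes no difference that can be told from the scatter; no measurement on hand speaks to what lies behind the aryl effect.

Going by these compounds, the two aryl groups differ in more than one substituent, so it stays open whether the trifluoromethyl group or the placing of the chlorine accounts for the step, and a plain phenyl ring or a ring carrying a nitrile in place of the trifluoromethyl could help to separate these. It also stays open whether the link would make as little difference with 3,5-dichlorophenyl, since the comparison shown holds only for 4-chloro-3-(trifluoromethyl)phenyl.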